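This account rests on a few compounds, and the source may have more. Where it says the series, first, only, none or still open, it means among the compounds named here.

Three compounds share one core and differ only in one group on a six-membered aromatic ring. Compound 1 `CCCc1ccc(/C=C/C(=O)Nc2ccc3nc(CCC)cc(N)c3c2)cc1` gives 4 nM in an assay on isolated protein for displacement of a labelled ligand from melanin-concentrating hormone receptor 1 (Homo sapiens); a lower number here means a stronger inhibitor, a higher number a weaker inhibitor. Compound 2 `CCCc1cc(N)c2cc(NC(=O)/C=C/c3ccc(N)cc3)ccc2n1` gives 190 nM in this assay, and compound 3 `CCCCc1ccc(/C=C/C(=O)Nc2ccc3nc(CCC)cc(N)c3c2)cc1` gives 45 nM. Compound 3 therefore stands second highest of the three numbers: the step of a 4.2-fold lower number from compound 2 to compound 3 (0.63 log units; beyond the scatter) separates it from compound 2, and the step of an 11-fold higher number from compound 1 to compound 3 (1.05 log units; beyond the scatter) separates it from compound 1. The change to compound 4 `CCCc1cc(N)c2cc(NC(=O)/C=C/c3ccc(I)cc3)ccc2n1` is iodo in place of butyl on an aromatic carbon. Going by the values given here, two measured steps bear on this. The step of a 4.2-fold lower number from compound 2 to compound 3 (0.63 log units; beyond the scatter) shows a modest gain when butyl replaced amino on this aromatic carbon, and the step of a 48-fold higher number from compound 1 to compound 2 (1.68 log units; beyond the scatter) shows a large loss when amino replaced propyl there, so among these three compounds the carbon groups gave lower numbers than amino. Among the compounds with values here, no measured compound carries a halogen on this aromatic carbon, so the size of the step cannot be read off directly. Iodo enters with no hydrogen-bond donors or acceptors, as the carbon groups do, so compound 4 is expected to give a lower number than compound 3, by about a 3.8-fold lower number from compound 3 to compound 4 (0.57 log units; beyond the scatter). The estimate for compound 4 is 12 nM, with a range from 3 nM to 50 nM.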

Compound 4, half-maximal inhibitory concentration: 2.3 nM
For compound 4 the middle estimate is 5.2-fold (0.72 log units) above the measured one, outside the stated range (below it).
By their numbers in this assay, from the lowest: compounds 4 and 1 (each within the scatter of the next); then compound 3; then compound 2.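

Iodo does as well here as propyl, the best carbon chain shown: the step of a 1.7-fold lower number from compound 1 to compound 4 (0.24 log units; within the scatter) cannot separate the two groups. The earlier compounds shown here suggested that carbon groups gave lower numbers than amino, but iodo, like amino, contains no carbon, and the step of an 83-fold lower number from compound 2 to compound 4 (1.92 log units; beyond the scatter) shows that a carbon chain is not needed for a low number at this position. The step of a 20-fold lower number from compound 3 to compound 4 (1.29 log units; beyond the scatter) also shows that replacing butyl, with 4 heavy atoms, by iodo, with 1 heavy atom, can give a much lower number, so among these compounds a larger group at this position does not give the lower number.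

The data shown give no explanation for why iodo and propyl sit level while butyl and amino give higher numbers. As far as these compounds go, it remains open whether other halogens, such as bromo or chloro, would match iodo, and whether a shorter chain, such as ethyl, would match propyl or fall closer to amino.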